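The source may hold more compounds than are shown below. What is called first, only, known or untested is meant among the compounds shown, and "the series" means these compounds.

Measured compounds:
- compound 1, `CCCCNc1nc(N)nc2c1CN(S(C)(=O)=O)CC2`: 9.9 uM
- compound 2, `CCCCNc1nc(N)nc2c1CN(Cc1cccnc1)CC2`: 0.13 uM
- compound 3, `CCCCNc1nc(N)nc2c1CN(Cc1ccco1)CC2`: 0.08 uM

In an assay on HEK293 cells for agonist activity at Toll-like receptor 8 (Homo sapiens), read by a luciferase reporter, with a stated time of 6 h (a higher number here means that more compound is needed for the effect, a lower number that less compound is needed), compound 3 gives the lowest number of the three. Its nearest neighbour is compound 2, which in this assay gives 0.13 uM, and the step of a 1.6-fold lower number from compound 2 to compound 3 (0.21 log units; within the scatter) lies within the scatter, so the two cannot be ranked. Compound 1, which gives 9.9 uM, stands far apart: the step of a 120-fold lower number from compound 1 to compound 3 (2.09 log units; beyond the scatter) and the related step of a 76-fold lower number from compound 1 to compound 2 (1.88 log units; beyond the scatter) are both large.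

Compound 4, `CCCCNc1nc(N)nc2c1CN(C(=O)c1cnccn1)CC2`, is not yet measured. It differs from compound 3 by (pyrazin-2-yl)carbonyl in place of (furan-2-yl)methyl on an amine nitrogen in a ring.

Among the compounds with values here, no measured step exchanges a methylene link for a carbonyl on this ring nitrogen, so the change is only partly covered. The step of a 1.6-fold lower number from compound 2 to compound 3 (0.21 log units; within the scatter) shows that exchanging one aromatic ring for another on the saturated carbon changed little. The steps from compound 1, where methylsulfonyl rather than an arylmethyl group sat on the nitrogen, show that the nature of the group on that nitrogen can move the number a great deal. Compound 4 carries a (pyrazin-2-yl)carbonyl, which is neither of the two kinds seen, and the author therefore expects a step of a 19-fold higher number from compound 3 to compound 4 (1.27 log units; beyond the scatter) toward a higher number, beyond the scatter but smaller than the steps from compound 1. Compound 4 is thus estimated to give 1.5 uM, within a range from 0.3 uM to 8 uM.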

Compound 4, minimum effective concentration: 2.2 uM
Compound 4: middle estimate off by 1.5-fold (0.17 log units), on the low side, and the stated range covers the measured number.
By their numbers in this assay, from the lowest: compounds 3 and 2 (each within the scatter of the next); then compound 4; then compound 1.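

In this assay, within the data shown here, the (pyrazin-2-yl)carbonyl is the first group on this amine nitrogen in a ring to be joined through a carbonyl, and it gives a 28-fold higher number from compound 3 to compound 4 (1.44 log units; beyond the scatter) and a 17-fold higher number from compound 2 to compound 4 (1.23 log units; beyond the scatter) as steps from the two arylmethyl compounds, both of them large, whereas exchanging the aromatic ring alone on the saturated carbon had stayed within the scatter. Against the methylsulfonyl group it gives a 4.5-fold lower number from compound 1 to compound 4 (0.65 log units; beyond the scatter) as a modest step, so compound 4 takes a place of its own in the order, and among these four compounds both groups without a saturated carbon on the nitrogen give higher numbers than both arylmethyl groups, with none going against this. No measurement of any property or of any interaction accompanies these numbers, so the steps can be stated but not explained. From the compounds shown here alone, the aromatic ring and the link changed together from compound 3 to compound 4, so what each contributes stays open, and a (pyrazin-2-yl)methyl or a (furan-2-yl)carbonyl group on the same nitrogen would separate the two. How a plain alkyl group such as ethyl, or the free ring amine with only hydrogen on that nitrogen, would stand against these four also remains unknown from the compounds shown.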